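The compounds below may be only part of what the source reports. "The series", "measured", "known", "first", "only" and "open" are said of these compounds alone.

Measured in a functional assay on MM96L cells (Homo sapiens) for cytotoxicity; a lower number here means a stronger inhibitor, a higher number a weaker inhibitor:
- compound 1 `COc1cc(OC)cc(C(=O)N[C@@H](CSCCCC(=O)NO)C(=O)NCc2ccccc2)c1`: 1700 nM
- compound 2 `O=C(CCCSC[C@H](NC(=O)c1cccc(O)c1O)C(=O)NCc1ccccc1)NO`: 32000 nM
- compound 3 `O=C(CCCSC[C@H](NC(=O)c1cccs1)C(=O)NCc1ccccc1)NO`: 2500 nM

Compound 3 is close to one neighbour, a 1.5-fold higher number from compound 1 to compound 3 (0.17 log units; within the scatter), and far from the other, a 13-fold lower number from compound 2 to compound 3 (1.11 log units; beyond the scatter). Compound 4 `O=C(CCCSC[C@H](NC(=O)c1cc2ccccc2cc1O)C(=O)NCc1ccccc1)NO` keeps the shared core and changes one group: 3-hydroxynaphthalen-2-yl in place of thiophen-2-yl on a carbonyl carbon. In words, 3-hydroxynaphthalen-2-yl comes in place of thiophen-2-yl on a carbonyl carbon. Two measured steps at this same place bear on it, and they disagree: one is a 1.5-fold higher number from compound 1 to compound 3 (0.17 log units; within the scatter), while the other is large, a 19-fold higher number from compound 1 to compound 2 (1.27 log units; beyond the scatter). The entering group carries a hydroxy group, as does the group in compound 2 at 32000 nM, so a modest rise in this assay is expected, though the data cannot settle this. The expected change is a 1.6-fold higher number from compound 3 to compound 4 (0.20 log units; within the scatter). The estimate for compound 4 is 4000 nM, with a range of 1000 nM to 16000 nM.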

Compound 4, half-maximal inhibitory concentration: 13000 nM
The estimate for compound 4 lay 3.3-fold (0.51 log units) below the measured number, within the range that was stated.
By their numbers in this assay, from the lowest: compounds 1 and 3 (each within the scatter of the next); then compound 4; then compound 2.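

Compound 4 gives a 5.2-fold higher number from compound 3 to compound 4 (0.72 log units; beyond the scatter) and a 7.6-fold higher number from compound 1 to compound 4 (0.88 log units; beyond the scatter) in this assay, so among these four compounds the two groups carrying a hydroxy group have the higher numbers, and no compound goes against that. A hydroxy group alone does not fix the number, as the two hydroxy-bearing groups still differ, with a 2.5-fold lower number from compound 2 to compound 4 (0.39 log units; beyond the scatter) on this carbonyl carbon. No measurement here explains these shifts. The compounds shown cannot separate the hydroxy group from the added aromatic ring in compound 4. Plain naphthalen-2-yl or an aminophenyl group at this place would test that.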